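The compounds below may be only part of what the source reports. "The series", "measured", "known", "first", "only" and "open" are said of these compounds alone.

In a physicochemical assay for lipophilicity (on this read-out lower numbers stand for lower lipophilicity and higher numbers for higher lipophilicity), compound 1 `CNC(=O)c1cc(C(=O)N[C@H]2[C@@H]3C[C@H](O)C[C@@H]32)n([C@@H](C)c2cccc(Cl)c2)n1` gives 3.7, at the upper end of the three numbers available. Compound 2 `CC[C@@H](c1ccccc1)n1nc(C(=O)NC)cc1C(=O)N[C@H]1[C@@H]2C[C@H](O)C[C@@H]21` gives 3.6, which is within the usual scatter of compound 1. Compound 3 `CNC(=O)c1cc(C(=O)N[C@H]2CC[C@H](O)CC2)c([C@@H](C)c2cccc(C)c2)o1` gives 3.3, lower than compound 1 by more than the scatter.

Compound 4 `CNC(=O)c1cc(C(=O)N[C@H]2[C@@H]3C[C@@H](O)C[C@@H]32)n([C@@H](C)c2cccc(Cl)c2)n1` has not yet been measured. Its relation to compound 1 is the two compounds have the same atoms and bonds and differ only in configuration as drawn: 1 of 5 stereo elements differ; a stereocentre at a saturated ring carbon is drawn S in compound 1 and R in compound 4: a stereocentre at a saturated ring carbon is drawn S in compound 1 and R in compound 4.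

Only one measured step links two of these compounds at a single place. That step, 1-phenylpropyl in place of 1-(3-chlorophenyl)ethyl on an aromatic nitrogen, is a number 0.10 log units lower from compound 1 to compound 2 (within the scatter). Among the measured compounds shown here, it concerns a different part of the molecule, and no measured pair here differs only in configuration, so the data offer only weak guidance. No step beyond the scatter is expected, in either direction.

The estimated step is no change at the digits printed from compound 1 to compound 4 (within the scatter).

The expected value for compound 4 is 3.7, with an estimated range from 3.4 to 4.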

Compound 4, distribution coefficient: 3.4
Compound 4: middle estimate off by 0.30 log units, on the high side; measured number inside the range.
By their numbers in this assay, from the lowest: compounds 3, 4, 2 and 1 (each within the scatter of the next, the first and the last beyond it).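

Among the compounds shown here, until now, no measured pair tested configuration; the only earlier step concerned the group on the aromatic nitrogen. In this assay, inverting this one stereocentre at a saturated ring carbon gives a number 0.30 log units lower from compound 1 to compound 4 (within the scatter), so on this read-out the drawn configuration at this position has no effect that can be told apart from the scatter. The pair is a clean test of that one stereocentre because nothing else separates the two structures: the fact that compounds 1 and 4 differ only in the configuration as drawn.

From the compounds shown here alone, whether the same inversion gives a similar step with 1-phenylpropyl on the aromatic nitrogen, as in compound 2, remains open. Also open, going by these compounds, is what number an amine or a carboxylic acid on this saturated ring carbon would give, in either configuration.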